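This account rests on a few compounds, and the source may have more. Where it says the series, first, only, none or still open, it means among the compounds named here.

In an ADME assay on HepG2 2.2.15 cells (Homo sapiens) for cytotoxicity (a higher number here means that more compound is tolerated, a lower number that less compound is tolerated), compound 1 `CCOCC(=O)OCCc1c(-c2ccccc2Cl)c2cc(Cl)ccc2[nH]c1=O`, which carries ethoxymethyl on a carbonyl carbon, gives 130000 nM. Compound 2 `COc1cccc(/C=C/C(=O)OCCc2c(-c3ccccc3Cl)c3cc(Cl)ccc3[nH]c2=O)c1` has 2-(3-methoxyphenyl)ethenyl on that carbon instead. Compound 2 reads > 1300000 nM, which is a limit of the assay and not a number. That places compound 2 at the limit of > 1300000 nM in this assay, at which 1 of the 2 values shown sits.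

The next compound, compound 3 `COc1ccc(/C=C/C(=O)OCCc2c(-c3ccccc3Cl)c3cc(Cl)ccc3[nH]c2=O)cc1`, differs from compound 2 in one place: 4-methoxyphenyl in place of 3-methoxyphenyl on a double-bonded chain carbon bound to a double-bonded chain carbon. In words, 4-methoxyphenyl stands in place of 3-methoxyphenyl on a double-bonded chain carbon bound to a double-bonded chain carbon. The two compounds have the same atoms, joined differently.

Among the compounds with values here, only one measured step bears on this change, and it is an indirect guide. It shows an at least 10-fold higher number from compound 1 to compound 2 (1.00 log units; beyond the scatter), a change beyond the scatter, but that step replaced the whole ethoxymethyl group, whereas compound 3 keeps the same atoms as compound 2. No step beyond the scatter is therefore expected in this assay. The expected step is a number no higher from compound 2 to compound 3 (the limit leaves the size open). For compound 3 the estimate is 1300000 nM, with an expected range from 400000 nM to 2600000 nM.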

Compound 3, half-maximal cytotoxic concentration: > 1200000 nM
Compound 3: no number, only a limit (the forecaster's own chance of this, stated with the estimate: 60%); the middle value does not contradict the limit.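

In this assay, compound 3 also ends at a limit of the assay and not at a number: the limit of > 1200000 nM in this assay, at which 1 of the 3 values shown sits.

The new information comes from the comparison with compound 1, where 2-(4-methoxyphenyl)ethenyl stands in place of ethoxymethyl on a carbonyl carbon and the result is an at least 9.2-fold higher number from compound 1 to compound 3 (0.96 log units; beyond the scatter). The rise in tolerated compound is therefore not confined to the 2-(3-methoxyphenyl)ethenyl group of compound 2, but appears with both methoxyphenyl forms shown here. Compound 2 also stands at a limit, so the step between the two isomers cannot be read, and the assay gives no ordering of 3-methoxyphenyl and 4-methoxyphenyl at this position.

Going by these compounds, how much compound can be tolerated with either isomer remains open, as does whether any true difference between them lies hidden beyond the limits. On these data alone, it is also open whether the methoxy group matters for the higher number, which a plain phenyl on the ethenyl chain would test, and whether a dimethylamino group or a carboxylic acid on that ring would keep the number this high.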